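Swapping Furan for Phenyl on a Demethylase Inhibitor

The source may report more compounds than this note shows. Statements on the series, on what has been measured and on what is new or still open speak of the compounds shown alone.

Of the compounds shown here, three have been tested in an assay on isolated protein for inhibition of lysine-specific demethylase 5C (Homo sapiens), read by AlphaScreen, with stated times of 15 min and 20 min; on this read-out lower numbers stand for stronger inhibition and higher numbers for weaker inhibition. Compound 1 `Nc1nc(-c2cc(C(=O)O)ccn2)cs1` gives 12 nM. Among the measured compounds shown here, compound 2 `Cc1nc(-c2cc(C(=O)O)ccn2)cs1` gives 1700 nM, and the step of a 140-fold higher number from compound 1 to compound 2 (2.15 log units; beyond the scatter) is the only single-point change measured so far. Compound 3 `O=C(O)c1ccnc(CNCc2ccco2)c1` gives 30 nM, which places it second highest of the three numbers: its nearest neighbour is compound 1, set apart by a gap beyond the usual scatter, while compound 2 lies much further off, also beyond the scatter.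

Compound 4 `O=C(O)c1ccnc(CNCc2ccccc2)c1` has not yet been measured in this assay. It differs from compound 3 in one place: phenyl in place of furan-2-yl on a saturated chain carbon bound to an amine nitrogen. For the measured compounds named here, no measured step bears on this change. Going by the values given here, the one step recorded, from compound 1 to compound 2, concerns a group on an aromatic carbon of the shared core and cannot tell how the exchange of one ring for another on the chain will turn out. With nothing to guide the direction, the expectation is a step of modest size, a 1.3-fold higher number from compound 3 to compound 4 (0.12 log units; within the scatter), on the assumption that compound 4 behaves much like compound 3. Compound 4 is therefore estimated at 40 nM in this assay, with a likely range from 12 nM to 130 nM.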

Compound 4, half-maximal inhibitory concentration: 60 nM
For compound 4 the middle estimate is 1.5-fold (0.18 log units) below the measured one; low and high end bracket the measured number.
By their numbers in this assay, from the lowest: compound 1; then compounds 3 and 4 (each within the scatter of the next); then compound 2.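

In this assay, the exchange of furan-2-yl for phenyl on a saturated chain carbon bound to an amine nitrogen gives a 2.0-fold higher number from compound 3 to compound 4 (0.30 log units; within the scatter), so this read-out does not separate the two rings at this place. Among the compounds shown here, the five-membered aromatic ring with its one hetero atom gives way to a six-membered aromatic ring of carbon only, and the hydrogen-bond acceptor counted on furan-2-yl goes with it, yet the step stays within the usual scatter, which the earlier compounds could not show because their one step, a 140-fold higher number from compound 1 to compound 2 (2.15 log units; beyond the scatter), concerns a different place. Nothing on hand explains this outcome.

From the compounds shown here alone, it remains open whether a saturated ring such as cyclohexyl, a longer chain carrying the phenyl, or a chlorine on the phenyl would keep the number in the same range. Compound 1 and compound 3 differ in more than one place, so their values cannot tell which single change matters when the chain replaces the group on the core of compound 1.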